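The source may hold more compounds than are shown below. What is called first, only, known or untested is meant among the compounds shown, and "the series" means these compounds.

Compound 1 `Cc1cc(NC(=O)c2cccc(C(F)(F)F)c2)ccc1NS(=O)(=O)C(F)(F)F` gives 8720 nM in an ADME assay on RAW264.7 cells (Mus musculus) for cytotoxicity, read by MTT assay, with a stated time of 48 h; a lower number here means a stronger inhibitor, a higher number a weaker inhibitor. Compound 2 `CS(=O)(=O)Nc1ccc(NC(=O)c2cccc(C(F)(F)F)c2)cc1Cl` gives > 250000 nM in this assay, which is a limit of the assay and not a number. Compound 3 `CS(=O)(=O)Nc1ccc(NC(=O)c2cc(C(F)(F)F)cc(C(F)(F)F)c2)cc1Cl` gives 69600 nM in this assay.

Compound 2 thus stands at the limit, the weakest reading the assay reports (the limit of > 250000 nM in this assay, at which 1 of the 3 values shown sits). Compound 4 `O=C(Nc1ccc(NS(=O)(=O)C(F)(F)F)c(Cl)c1)c1cccc(C(F)(F)F)c1` differs from compound 2 by trifluoromethyl in place of methyl on a sulfonyl sulfur. Among the compounds with values here, the only measured step from compound 2 is an at least 3.5-fold lower number from compound 2 to compound 3 (0.55 log units; beyond the scatter); it alters the benzamide side and not the sulfonyl, so it offers no direct guide. Within the data shown here, compound 1 carries the (trifluoromethyl)sulfonyl group and gives 8720 nM, but it also differs from compound 4 in the ring substituent, and no step between them is measured. The account therefore rests on the shared pattern that the three values show. For compound 4 a lower number than the limit of compound 2 is expected, a step of an at least 12-fold lower number from compound 2 to compound 4 (1.09 log units; beyond the scatter). Compound 4 is estimated at 20000 nM, within a range from 5000 nM to 150000 nM.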

Compound 4, half-maximal inhibitory concentration: 55800 nM
Compound 4: middle estimate off by 2.8-fold (0.45 log units), on the low side; the measured number falls inside the stated range.
By their numbers in this assay, from the lowest: compound 1; then compounds 4 and 3 (each within the scatter of the next). At a limit, above all of these: compound 2.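

Compound 2 is held at a limit of the assay and not at a number: the limit of > 250000 nM in this assay, at which 1 of the 4 values shown sits.

Within the data shown here, the change on the sulfonyl sulfur can now be read for the first time: trifluoromethyl in place of methyl gives an at least 4.4-fold lower number from compound 2 to compound 4 (0.65 log units; beyond the scatter) in this assay, a step known only as a bound. The aromatic substituent also proves to count with the (trifluoromethyl)sulfonyl group held constant, as chloro in place of methyl on an aromatic carbon gives a 6.4-fold higher number from compound 1 to compound 4 (0.81 log units; beyond the scatter).

Going by these compounds, it remains open whether that chloro and methyl difference would carry over to the methylsulfonyl series, and whether the added trifluoromethyl on the benzamide side would act the same way with a (trifluoromethyl)sulfonyl group. On these data alone, how a longer chain such as ethyl, or a phenyl ring, would read on the sulfonyl sulfur also remains open.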